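Phenol in Place of Trifluoromethyl on a Shared Bicyclic Core

The source may report more compounds than this note shows. Statements on the series, on what has been measured and on what is new or still open speak of the compounds shown alone.

Measured so far:
Compound 1, `Cc1nc2sc(-c3ccc(F)cc3)nc2c(=O)[nH]1`, 1%
Compound 2, `Cc1nc2sc(-c3ccc(C(F)(F)F)cc3)nc2c(=O)[nH]1`, 1%

Both compounds share a core that carries a phenyl ring bearing one substituent. In an assay on CHO cells for displacement of a labelled ligand from adenosine receptor A1 (Homo sapiens), read by scintillation counting, with a stated time of 120 min, tested at 1 uM (on this read-out higher numbers stand for more inhibition at the one concentration tested (going by the name of the read-out) and lower numbers for less inhibition), compound 1 gives 1%. Compound 2 carries a trifluoromethyl in place of the fluoro, and the step of no change at the digits printed from compound 1 to compound 2 (within the scatter), so compound 2 stands level with compound 1 in this assay, both at the bottom of the scale.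

Compound 3, `Cc1nc2sc(-c3ccc(O)cc3)nc2c(=O)[nH]1`, is not yet measured. It differs from compound 2 by hydroxy in place of trifluoromethyl on an aromatic carbon. Among the measured compounds shown here, only one measured step exists, and it concerns a different group; it was flat. For the measured compounds named here, no measured step involves a hydroxy, so no size can be read off for this change. Given the flat step, compound 3 is expected to stay near compound 2, with the step of a number 4 percentage points higher from compound 2 to compound 3 (within the scatter) expected. The estimate for compound 3 is 5%, within 0% to 25%.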

Compound 3, a percentage reported as inhibition, at one concentration (the size of the read-out at that concentration, not a potency): 1%
For compound 3 the middle estimate is 4 percentage points above the measured one; measured number inside the range.
By their numbers in this assay, from the lowest: compounds 1, 2 and 3 (each within the scatter of the next).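

In this assay, the exchange on the aromatic carbon gives no change at the digits printed from compound 2 to compound 3 (within the scatter) and no change at the digits printed from compound 1 to compound 3 (within the scatter) when hydroxy enters. The earlier step swapped only fluoro for trifluoromethyl, whereas this one brings in a group with 1 hydrogen-bond donor and 1 hydrogen-bond acceptor in place of a group with 0 of each, and that difference leaves the reading flat at this one concentration. Nothing available explains this flat result.

As far as these compounds go, whether an amine, a carboxylic acid or a longer chain such as butoxy on this carbon would lift the reading remains open. With all three compounds level, these data also cannot show whether this position matters at all for displacement of the labelled ligand, or whether changes elsewhere on the shared core would be needed first.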